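Aryl sulfone to oxanyl sulfone in a urea series

The source may hold more compounds than are shown below. What is called first, only, known or untested is meant among the compounds shown, and "the series" means these compounds.

compound 1 `O=C(NCc1ccc(S(=O)(=O)c2ccccc2)cc1)NCc1cccnc1` — 19 nM
compound 2 `O=S(=O)(c1ccccc1)c1ccc(CNS(=O)(=O)N2Cc3ccncc3C2)cc1` — only a limit, > 2000 nM
compound 3 `O=C(NCc1ccc(S(=O)(=O)c2cc(F)cc(F)c2)cc1)N1Cc2ccncc2C1` — 7.1 nM

In an assay on isolated protein for inhibition of Nicotinamide phosphoribosyltransferase (Homo sapiens), read by mass spectrometry, with stated times of 15 min and 30 min (a higher number here means a weaker inhibitor, a lower number a stronger inhibitor), compound 1 gives 19 nM. For compound 2 the assay reports only a limit, > 2000 nM. Compound 3 gives 7.1 nM, the lowest of the two numbers; compound 1 stands at a higher number, a gap beyond the scatter. Compound 4 `O=C(NCc1ccc(S(=O)(=O)C2CCCOC2)cc1)N1Cc2ccncc2C1` differs from compound 3 by oxan-3-yl in place of 3,5-difluorophenyl on a sulfonyl sulfur. Among the compounds with values here, no pair of measured compounds is separated by this change alone, so its size is open. A moderate rise in the number, beyond the scatter, is expected, and the step from compound 3 to compound 4 is estimated as a 4.2-fold higher number from compound 3 to compound 4 (0.63 log units; beyond the scatter). Compound 4 is therefore estimated at 30 nM, within 8 nM to 150 nM.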

Compound 4, half-maximal inhibitory concentration: 44 nM
Compound 4: the middle estimate sits 1.5-fold (0.17 log units) below what was measured, within the range that was stated.
By their numbers in this assay, from the lowest: compound 3; then compound 1; then compound 4. At a limit, above all of these: compound 2.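

Replacing the aromatic ring on the sulfonyl sulfur with a non-aromatic one weakens inhibition without abolishing it: in this assay the change gives a 6.2-fold higher number from compound 3 to compound 4 (0.79 log units; beyond the scatter), and compound 4 still reads 44 nM. This position therefore accepts oxan-3-yl, and an aromatic ring is not required there. No measurement shown accounts for the size of this step.

As far as these compounds go, whether the step follows the ring oxygen, the missing fluorine atoms or the lost aromaticity stays open, for this single pair changes all three together. Cyclohexyl or piperidin-4-yl on the same sulfonyl sulfur would begin to separate them.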